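The compounds below may be only part of what the source reports. "The series", "measured", "known", "first", "only" and "open" are said of these compounds alone.

Of the compounds shown here, two of a shared core have been measured so far. Compound 1 `CC(/C=C/CC(C)CCCC(C)C)=C\C(=O)OC(C)(C)C` carries a tert-butoxy group on its carbonyl carbon; in a physicochemical assay for lipophilicity (on this read-out lower numbers stand for lower lipophilicity and higher numbers for higher lipophilicity), compound 1 gives 7.56. Going by the values given here, compound 2 `CCN(CC)C(=O)/C=C(C)/C=C/CC(C)CCCC(C)C` has a diethylamino group in that place instead, and in this assay compound 2 gives 6.02, the lower of the two numbers known. Among the compounds with values here, the one step measured, a number 1.54 log units lower from compound 1 to compound 2 (beyond the scatter), shows how much that single exchange moved the read-out.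

Compound 3 `CC(/C=C/CC(C)CCCC(C)C)=C\C(=O)c1ccccc1` is not yet measured. It differs from compound 2 in one place: phenyl in place of diethylamino on a carbonyl carbon. Within the data shown here, the step from compound 1 to compound 2 bears on this change only in part, since it tells what the diethylamino group did on entering, and here that group leaves again; no measured compound shows what a phenyl group does on this carbonyl carbon. Because a number 1.54 log units lower from compound 1 to compound 2 (beyond the scatter) was large, removing the diethylamino group is expected to push the number back up by a large step, estimated as a number 1.58 log units higher from compound 2 to compound 3 (beyond the scatter). For compound 3 the expected result in this assay is therefore 7.6, within a range from 6.9 to 8.3.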

Compound 3, partition coefficient: 7.26
Beside the measured number, compound 3's estimate is 0.34 log units above it, and the stated range covers the measured number.
By their numbers in this assay, from the lowest: compound 2; then compounds 3 and 1 (each within the scatter of the next).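

On the carbonyl carbon of the shared core, phenyl now stands as a third group, and in this assay putting it in place of diethylamino gives a number 1.24 log units higher from compound 2 to compound 3 (beyond the scatter) and so shows a second large step at this one place. Phenyl in place of tert-butoxy gives a number 0.30 log units lower from compound 1 to compound 3 (within the scatter) and so leaves compound 1 and compound 3 indistinguishable on this read-out, even though the two groups differ in kind, which makes compound 2, with diethylamino, the one that stands apart among these three. No measurement on hand explains why these numbers fall as they do.

Going by these compounds, it stays open whether other amines on this carbonyl carbon, such as dimethylamino or piperidine, would sit near compound 2 or near the other two compounds, and whether a smaller ester such as methoxy would sit near compound 1. Also open, on these data alone, is how a phenyl ring carrying a fluorine or a methoxy group, or a pyridine ring in its place, would read in this assay on the same shared core.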